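Replacing Methoxy with Trifluoromethoxy on a Bromoacrylamide Series

The source may report more compounds than this note shows. Statements on the series, on what has been measured and on what is new or still open speak of the compounds shown alone.

Values so far in a functional assay on LoVo cells (Homo sapiens) for inhibition, read by MTT assay, with a stated time of 72 h (on this read-out lower numbers stand for stronger inhibition and higher numbers for weaker inhibition), are these:
- compound 1 `C=C(Br)C(=O)Nc1cccc(/C=C/C(=O)Nc2ccccc2)c1` at 3900 nM
- compound 2 `C=C(Br)C(=O)Nc1cccc(/C=C/C(=O)Nc2ccc(C)cc2)c1` at 1500 nM
- compound 3 `C=C(Br)C(=O)Nc1cccc(/C=C/C(=O)Nc2ccc(OC)cc2)c1` at 550 nM

Compound 3 holds the lowest number of the three (550 nM) and is the most potent so far. The next compound, compound 4 `C=C(Br)C(=O)Nc1cccc(/C=C/C(=O)Nc2ccc(OC(F)(F)F)cc2)c1`, differs from it by trifluoromethyl in place of methyl on an oxygen on an aromatic ring in one place: trifluoromethyl in place of methyl on an oxygen on an aromatic ring, which turns methoxy to trifluoromethoxy.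

For the measured compounds named here, no measured step covers this exchange directly. The nearest evidence is a 7.1-fold lower number from compound 1 to compound 3 (0.85 log units; beyond the scatter) and a 2.7-fold lower number from compound 2 to compound 3 (0.44 log units; beyond the scatter) alongside a 2.6-fold lower number from compound 1 to compound 2 (0.41 log units; beyond the scatter) and all three are modest. They show that a change at this group moved the number only modestly, but they do not settle the direction for trifluoromethoxy. A modest step in this assay is therefore expected, leaning slightly towards a higher number. The estimated step is a 1.5-fold higher number from compound 3 to compound 4 (0.16 log units; within the scatter) and it may not clear the usual scatter. Compound 4 is expected at 800 nM with an estimated range of 250 nM to 2500 nM until its measurement is known.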

Compound 4, half-maximal inhibitory concentration: 30300 nM
For compound 4 the middle estimate is 38-fold (1.58 log units) below the measured one; the measured number lies above the stated range.
By their numbers in this assay, from the lowest: compound 3; then compound 2; then compound 1; then compound 4.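

In this assay, for the compounds shown here, the change from methoxy to trifluoromethoxy is the largest single move (a 55-fold higher number from compound 3 to compound 4 (1.74 log units; beyond the scatter)), so this position is far less tolerant than the steps among the earlier compounds suggested. Compound 4 also ranks behind both compound 2 (a 20-fold higher number from compound 2 to compound 4 (1.31 log units; beyond the scatter)) and compound 1, which carries only hydrogen at this place (a 7.8-fold higher number from compound 1 to compound 4 (0.89 log units; beyond the scatter)), so a group here can raise the number as well as lower it, and the fall from hydrogen through methyl to methoxy does not extend to trifluoromethoxy. Nothing available explains this reversal.

The compounds shown leave open whether the loss is specific to trifluoromethyl on the oxygen or would also appear with ethoxy on the same aromatic carbon. They also leave open how an amine or a chlorine there would compare with methoxy.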